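Methyl on the Phenolic Oxygen, Applied a Second Time

A few compounds are considered here, and "the series" means these few. Any claim that something is new, unique, unknown or untested is made for them only; others in the source may bear on it.

Compound 1 `COc1cc(OC)cc(-c2ccc(-c3ccc(O)cc3)cc2)c1` and compound 3 `COc1cc(OC)cc(-c2ccccc2-c2ccc(O)cc2)c1` are built from the same atoms joined differently; the difference between the two cores is not broken down here. In a functional assay on HL-60 cells (Homo sapiens) (on this read-out higher numbers stand for an effect only at larger amounts of compound and lower numbers for an effect already at smaller amounts), compound 1 gives 30000 nM. Compound 3 gives 10000 nM in this assay, the lower of the two numbers. Compound 2 `COc1ccc(-c2ccc(-c3cc(OC)cc(OC)c3)cc2)cc1` is compound 1 after one change, (methyl in place of hydrogen on an oxygen on an aromatic ring). For compound 2 this assay reports only a limit of > 100000 nM, not a number. That change produced an at least 3.3-fold higher number from compound 1 to compound 2 (0.52 log units; beyond the scatter), a figure that can only be given as a lower bound because of the limit of > 100000 nM in this assay, at which 1 of the 3 values shown sits. Compound 4 `COc1ccc(-c2ccccc2-c2cc(OC)cc(OC)c2)cc1` is the counterpart of compound 3, made by the same change, (methyl in place of hydrogen on an oxygen on an aromatic ring), at a place described in the same words. Compound 4 is therefore expected to show a 6.0-fold higher number from compound 3 to compound 4 (0.78 log units; beyond the scatter), an expectation resting on an at least 3.3-fold higher number from compound 1 to compound 2 (0.52 log units; beyond the scatter). The estimate for compound 4 in this assay is 60000 nM, expected to fall between 20000 nM and 200000 nM, with a real chance that only a limit is reported.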

Compound 4, concentration for half-maximal activity: 15000 nM
Estimate against measurement, compound 4: 4.0-fold (0.60 log units) above, outside the stated range (below it).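

Carried to the second core, the change from hydroxy to methoxy gives a 1.5-fold higher number from compound 3 to compound 4 (0.18 log units; within the scatter) in this assay. Going by these compounds alone, the step beyond the scatter seen on the first core thus has no counterpart of that kind here, yet this does not show that the change truly behaves differently on the two cores: the same change on two cores in this assay, an at least 3.3-fold higher number (0.52 log units; beyond the scatter) from compound 1 to compound 2 and a 1.5-fold higher number (0.18 log units; within the scatter) from compound 3 to compound 4; the limit leaves it open whether they differ. Compound 2 gives only a limit, > 100000 nM, and a single pair on each core is too little to support a rule for the series.

The compounds shown leave open how the same position would read in this assay with something other than hydroxy or methoxy, for instance a longer chain such as ethoxy, an amine or a carboxylic acid. They also leave open whether the size of the step on the first core could be settled by a third core carrying the same hydroxy to methoxy change.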